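Benzyl Ester to Free Acid in a Purine Series

A few compounds are considered here, and "the series" means these few. Any claim that something is new, unique, unknown or untested is made for them only; others in the source may bear on it.

Measured so far:
compound 1, `O=C(CN(c1nc(Cl)nc2[nH]cnc12)C1CC1)NCC(=O)OCc1ccccc1`, 27.2% in a functional assay on the whole organism (Tail, strain ICR) with Mus musculus as the target, in the tail flick test, with a stated time of 90 min, at a dose of 25 umol/kg by the oral route; on this read-out lower numbers stand for a weaker effect and higher numbers for a stronger effect at the one dose given
compound 2, `NCCCC[C@H](NC(=O)CN(c1nc(Cl)nc2[nH]cnc12)C1CC1)C(=O)OCc1ccccc1`, 35.3%

Two compounds share a core and differ at the chain that carries the ester. In this assay compound 1 gives 27.2%, the lower of the two numbers; compound 2 gives 35.3%. For the measured compounds named here, the one step available, a number 8.1 percentage points higher from compound 1 to compound 2 (within the scatter), stays within the scatter, so the two values cannot be ordered.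

Compound 3, `O=C(O)CNC(=O)CN(c1nc(Cl)nc2[nH]cnc12)C1CC1`, departs from compound 1 by hydrogen in place of benzyl on an oxygen next to a carbonyl group. Going by the values given here, no measured step touches this oxygen, so the single known step offers no guide to the size or direction of the change. With nothing pointing either way, the number for compound 3 is expected to stay near that of compound 1, and a number 2.2 percentage points lower from compound 1 to compound 3 (within the scatter) is the estimated step. The estimate for compound 3 is 25%, within 5% to 50%.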

Compound 3, a percentage reported as activity, at one dose (the size of the read-out at that dose, not a potency): 32.3%
Compound 3: middle estimate off by 7.3 percentage points, on the low side, within the range that was stated.
By their numbers in this assay, from the lowest: compounds 1, 3 and 2 (each within the scatter of the next).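

Exchanging benzyl for hydrogen on an oxygen next to a carbonyl group, which turns benzyloxy into hydroxy, gives in this assay a number 5.1 percentage points higher from compound 1 to compound 3 (within the scatter) and so opens no gap that can be told apart from repeat measurements. For the compounds shown here, the earlier step concerned the saturated chain carbon, so this is the first reading at the oxygen itself, and at this one dose the read-out does not separate the benzyl ester from the free carboxylic acid. No other measurement bears on this result, and the finding remains a bare comparison of two numbers.

A smaller ester such as a methyl or ethyl ester, or a primary amide at the same carbonyl, could still read differently. On these data alone, it also remains open whether the same exchange would read alike on the 4-aminobutyl chain of compound 2.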